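Exchanging 5-fluoropyridin-3-yl for 5-fluoropyridin-2-yl on an Oxygen

The source may report more compounds than this note shows. Statements on the series, on what has been measured and on what is new or still open speak of the compounds shown alone.

Of the compounds shown here, two sharing one core have been measured in an ADME assay on the whole organism (Rattus norvegicus) for pharmacokinetics, using cassette dosing, at a dose of 1 mg/kg by the oral route; on this read-out lower numbers stand for lower oral bioavailability and higher numbers for higher oral bioavailability. In this assay compound 1 `C[C@@H](Cn1c(=O)[nH]/c(=N\c2ccc(Oc3nccs3)cc2)n(Cc2ccc(Cl)cc2)c1=O)C(=O)O` gives 41.4%, while compound 2 `C[C@@H](Cn1c(=O)[nH]/c(=N\c2ccc(Oc3cncc(F)c3)cc2)n(Cc2ccc(Cl)cc2)c1=O)C(=O)O` gives 74.3%, the higher of the two numbers.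

Compound 3 `C[C@@H](Cn1c(=O)[nH]/c(=N\c2ccc(Oc3ccc(F)cn3)cc2)n(Cc2ccc(Cl)cc2)c1=O)C(=O)O` has not yet been measured. It carries 5-fluoropyridin-2-yl in place of 5-fluoropyridin-3-yl on an oxygen on an aromatic ring, the same atoms joined differently: 5-fluoropyridin-2-yl in place of 5-fluoropyridin-3-yl on an oxygen on an aromatic ring.

Among the compounds with values here, only one measured step bears on this change. That step is a number 32.9 percentage points higher from compound 1 to compound 2 (beyond the scatter), large and beyond the scatter, and it exchanged 1,3-thiazol-2-yl for 5-fluoropyridin-3-yl. It replaced one ring with a different one, whereas the new change keeps the same atoms, so a smaller step is expected. Within the data shown here, no measurement yet shows what 5-fluoropyridin-2-yl does here. Among the measured compounds shown here, with so few data, a modest fall from the higher of only two numbers seems the likelier direction. The expected move is a number 12.3 percentage points lower from compound 2 to compound 3 (beyond the scatter), and this estimate is uncertain. For compound 3 the estimated value is 62%, with an expected range from 40% to 84%.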

Compound 3, oral bioavailability: 82.4%
Compound 3: middle estimate off by 20.4 percentage points, on the low side, and the stated range covers the measured number.
By their numbers in this assay, from the lowest: compound 1; then compounds 2 and 3 (each within the scatter of the next).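

In this assay, the exchange of 5-fluoropyridin-3-yl for 5-fluoropyridin-2-yl on an oxygen on an aromatic ring gives a number 8.1 percentage points higher from compound 2 to compound 3 (within the scatter), so this read-out does not separate the two ways of joining the same atoms. The exchange of 1,3-thiazol-2-yl for 5-fluoropyridin-2-yl gives a number 41 percentage points higher from compound 1 to compound 3 (beyond the scatter), which shows that the large difference from the thiazole is not confined to one of the two fluoropyridines but holds for both compounds that carry such a ring at this position. No data are at hand that would explain either step.

As far as these compounds go, whether the fluorine matters remains open, since a pyridin-2-yl ring without it, or one carrying a nitrile or a methoxy group in its place, could hold this level or lose it, and a plain phenyl ring on the oxygen would test whether the ring nitrogen matters at all. From the compounds shown here alone, it is also open whether the two fluoropyridines stay this close outside this assay, which covers a single species, dose and route.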